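This account rests on a few compounds, and the source may have more. Where it says the series, first, only, none or still open, it means among the compounds named here.

Compound 2 `CNC(=O)c1cc(Oc2ccc3oc(Nc4cccc(C(F)(F)F)c4)nc3c2)ccn1` was tested in an ADME assay on Caco-2 cells (Homo sapiens) for permeability, in the apical to basolateral direction (on this read-out lower numbers stand for lower permeability and higher numbers for higher permeability), and gave 10 10^-6 cm/s. Compound 1 `CNC(=O)c1cc(Oc2ccc3oc(Nc4ccccc4F)nc3c2)ccn1` gave 10 10^-6 cm/s in this assay, and the step of no change at the digits printed from compound 1 to compound 2 (within the scatter) was flat within the scatter. Compound 3 `CNC(=O)c1cc(Oc2ccc3oc(Nc4cccc(C(C)C)c4)nc3c2)ccn1` has not yet been measured; its difference from compound 2 is isopropyl in place of trifluoromethyl on an aromatic carbon. Within the data shown here, the one measured step that bears on this, the exchange of one substituted phenyl for another on the same nitrogen, produced no change, so for compound 3 no step beyond the scatter is expected in this assay, that is no change at the digits printed from compound 2 to compound 3 (within the scatter). Compound 3 is therefore estimated at 10 10^-6 cm/s, with a range of 5 10^-6 cm/s to 20 10^-6 cm/s.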

Compound 3, apparent permeability: 10 10^-6 cm/s
For compound 3 middle estimate and measured number coincide at the digits printed; low and high end bracket the measured number.
By their numbers in this assay, from the lowest: compounds 1, 2 and 3 (each within the scatter of the next).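

Replacing trifluoromethyl with isopropyl on this aromatic carbon gives no change at the digits printed from compound 2 to compound 3 (within the scatter) in this assay, so a group with fluorine and a group of carbon only read alike at this position. The broader exchange on the nitrogen, 3-isopropylphenyl for 2-fluorophenyl, gives no change at the digits printed from compound 1 to compound 3 (within the scatter) and likewise separates nothing. No measurement available here explains this flat result. Still open, on these data alone, is whether the read-out stays level with an amine or a carboxylic acid at this position, or with a longer chain.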